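From tert-Butyl to Fluoro in a Small Series

A few compounds are considered here, and "the series" means these few. Any claim that something is new, unique, unknown or untested is made for them only; others in the source may bear on it.

Measured in a functional assay on A549 cells (Homo sapiens) for inhibition, read by CCK-8 assay, with a stated time of 72 h, tested at 8 uM; on this read-out lower numbers stand for less inhibition of growth and higher numbers for more inhibition of growth at the one concentration tested:
Compound 1 `COc1ccc(SCc2ccc(C(=O)Nc3ccccc3N)cc2)cc1`: 70.7%
Compound 2 `Nc1ccccc1NC(=O)c1ccc(CSc2cccc(F)c2)cc1`: 72.7%
Compound 3 `CC(C)(C)c1ccc(SCc2ccc(C(=O)Nc3ccccc3N)cc2)cc1`: 67%

Compound 3, at 67%, stands within the scatter of both compound 1 and compound 2, so no order among the three can be read from these numbers. The next compound to be tested is compound 4 `Nc1ccccc1NC(=O)c1ccc(CSc2ccc(F)cc2)cc1`. It carries fluoro in place of tert-butyl on an aromatic carbon, para to a large group (fluoro in place of tert-butyl on an aromatic carbon).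

Among the measured compounds shown here, two measured steps bear on this change. Placing tert-butyl where methoxy stood gave a number 3.7 percentage points lower from compound 1 to compound 3 (within the scatter), and placing 3-fluorophenyl where 4-methoxyphenyl stood on a sulfur gave a number 2 percentage points higher from compound 1 to compound 2 (within the scatter). Neither step leaves the scatter, and compound 2, which also carries a fluoro, gives 72.7%. No step beyond the scatter is therefore expected in this assay. The expected change is a number 4 percentage points higher from compound 3 to compound 4 (within the scatter). The estimate for compound 4 is 71%, with an expected range from 62% to 79%.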

Compound 4, percent growth inhibition at one concentration: 44.5%
Estimate against measurement, compound 4: 26.5 percentage points above; measured number outside the range, below it.
By their numbers in this assay, from the lowest: compound 4; then compounds 3, 1 and 2 (each within the scatter of the next).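

In this assay, among the compounds shown here, this position proves not to be indifferent: fluoro in place of tert-butyl on an aromatic carbon gave a number 22.5 percentage points lower from compound 3 to compound 4 (beyond the scatter) in the first step to leave the scatter. Fluoro in place of methoxy gave a number 26.2 percentage points lower from compound 1 to compound 4 (beyond the scatter) as well, so at this place fluoro stands apart from both groups, which themselves lie within the scatter of each other. The presence of fluoro alone does not set the number, since 4-fluorophenyl in place of 3-fluorophenyl on a sulfur gave a number 28.2 percentage points lower from compound 2 to compound 4 (beyond the scatter) with the same atoms rearranged.

Nothing in the data shown accounts for these drops. As far as these compounds go, whether a chloro group or an amine at this place would stand with fluoro or with tert-butyl and methoxy remains open.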